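Trading a substituted phenyl for a fluorophenyl on the core

The compounds below may be only part of what the source reports. "The series", "measured", "known", "first", "only" and "open" are said of these compounds alone.

Compound 1 `COc1cc(-c2c(C)nn(-c3nc(-c4ccc(Cl)c(Cl)c4)c(SC(C)C)s3)c2C(=O)O)cc(C(F)(F)F)c1` is the starting point of this series. In a functional assay on BJAB cells (Homo sapiens) for antiproliferative activity, with a stated time of 4 days (on this read-out lower numbers stand for an effect already at smaller amounts and higher numbers for an effect only at larger amounts of compound), compound 1 gives 1380 nM, the lowest number among the three measured compounds. Compound 2 `Cc1nn(-c2nc(-c3ccc(Cl)c(Cl)c3)c(SC(C)C)s2)c(C(=O)O)c1-c1cncnc1` gives 22000 nM in this assay, and compound 3 `CCSc1sc(-n2nc(C)c(Cc3ccccc3[N+](=O)[O-])c2C(=O)O)nc1-c1ccc(Cl)c(Cl)c1` gives 59000 nM. Within the data shown here, the only single-site step measured so far is that from compound 1 to compound 2, where the number rose a 16-fold higher number from compound 1 to compound 2 (1.20 log units; beyond the scatter). Compound 3 differs from compound 1 in more than one place, so its value shows only that it lies well above compound 1.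

The new compound 4 `Cc1nn(-c2nc(-c3ccc(Cl)c(Cl)c3)c(SC(C)C)s2)c(C(=O)O)c1-c1cccc(F)c1` differs from compound 1 in one place: 3-fluorophenyl in place of 3-methoxy-5-(trifluoromethyl)phenyl on an aromatic carbon. This change keeps a six-membered aromatic ring of carbon only at the same position, unlike the pyrimidin-5-yl of compound 2, so the move is expected to be smaller than the step from compound 1 to compound 2. Compound 4 is therefore expected to give 3500 nM in this assay, within a range from 1200 nM to 12000 nM, an estimated step of a 2.5-fold higher number from compound 1 to compound 4 (0.40 log units; beyond the scatter) toward a higher number.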

Compound 4, half-maximal effective concentration: 900 nM
Estimate against measurement, compound 4: 3.9-fold (0.59 log units) above, outside the stated range (below it).
By their numbers in this assay, from the lowest: compounds 4 and 1 (each within the scatter of the next); then compound 2; then compound 3.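

In this assay the exchange of 3-methoxy-5-(trifluoromethyl)phenyl for 3-fluorophenyl gives a 1.5-fold lower number from compound 1 to compound 4 (0.19 log units; within the scatter) and so separates compound 4 from compound 1 by no more than the usual scatter, which shows that at this position a phenyl ring carrying only a fluorine matches the value of the ring carrying methoxy and trifluoromethyl. Compound 4 also lacks both of those groups, and the change from pyrimidin-5-yl to 3-fluorophenyl gives a 24-fold lower number from compound 2 to compound 4 (1.39 log units; beyond the scatter) as a large step. No measurement available here explains either result.

Still open, as far as these compounds go, is whether unsubstituted phenyl, or a phenyl ring bearing an amine or a hydroxyl group, would stay in the range of compound 1 and compound 4. A pyridin-3-yl ring, with a single ring nitrogen, would show how far the step seen with pyrimidin-5-yl follows the ring nitrogens.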